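Amide-to-sulfonamide chain swap on the ring nitrogen

A few compounds are considered here, and "the series" means these few. Any claim that something is new, unique, unknown or untested is made for them only; others in the source may bear on it.

Working notes on the series. Compound 1 `COc1cc(N)c(Cl)cc1C(=O)NC1CCN(CC2CCN(C(=O)CN)CC2)CC1` gives 9.3 nM in an assay on striatum for inhibition of 5-hydroxytryptamine receptor 4 (Cavia porcellus), read by radioligand binding; on this read-out higher numbers stand for weaker inhibition and lower numbers for stronger inhibition. Compound 2 `COc1cc(N)c(Cl)cc1C(=O)NC1CCN(CC2CCN(C(=O)C(C)(C)N)CC2)CC1` gives 2.6 nM in this assay, and compound 3 `COc1cc(N)c(Cl)cc1C(=O)NC1CCN(CC2CCN(C(=O)CCCN)CC2)CC1` gives 3.99 nM. Steps so far: a 3.6-fold lower number from compound 1 to compound 2 (0.55 log units; beyond the scatter); a 2.3-fold lower number from compound 1 to compound 3 (0.37 log units; beyond the scatter); a 1.5-fold higher number from compound 2 to compound 3 (0.19 log units; within the scatter). Compound 3 thus stands second highest of the three numbers, nearest compound 2 and furthest from compound 1.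

Compound 4 `COc1cc(N)c(Cl)cc1C(=O)NC1CCN(CC2CCN(CCCNS(C)(=O)=O)CC2)CC1` differs from compound 3 as follows: 3-(methanesulfonamido)propyl in place of (3-aminopropyl)carbonyl on an amine nitrogen in a ring. Within the data shown here, no measured step bears on this change; all three only lengthened or branched the amine-bearing chain on the carbonyl and stayed modest. Among the measured compounds shown here, with no close precedent, compound 4 is expected to lose some potency, estimated at 10 nM with a range of 2.5 nM to 40 nM. This estimate corresponds to an expected step of a 2.5-fold higher number from compound 3 to compound 4 (0.40 log units; beyond the scatter).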

Compound 4, half-maximal inhibitory concentration: 21.1 nM
Compound 4: middle estimate off by 2.1-fold (0.32 log units), on the low side; low and high end bracket the measured number.
By their numbers in this assay, from the lowest: compounds 2 and 3 (each within the scatter of the next); then compound 1; then compound 4.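

At this amine nitrogen in a ring, 3-(methanesulfonamido)propyl raises the number in this assay against all three acyl chains (a 5.3-fold higher number from compound 3 to compound 4 (0.72 log units; beyond the scatter)) (an 8.1-fold higher number from compound 2 to compound 4 (0.91 log units; beyond the scatter)) (a 2.3-fold higher number from compound 1 to compound 4 (0.36 log units; beyond the scatter)). Among these compounds, the earlier steps beyond the scatter all lowered the number, so this is the first change at the position that goes the other way. Nothing available accounts for this rise.

From the compounds shown here alone, it remains open whether the rise follows from losing the carbonyl or from gaining the sulfonamide end. A plain 3-aminopropyl chain on this nitrogen, or an acetamido end in place of methanesulfonamido, would separate the two.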